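Phenoxy in Place of a Cyclohexenylmethyl Group: Expectation

This account rests on a few compounds, and the source may have more. Where it says the series, first, only, none or still open, it means among the compounds named here.

Measured compounds:
compound 1 `CCOC(=O)c1cnc(-n2nc(C)cc2C)nc1NN1C(=O)C=C(C)C1=O` 10000 nM
compound 2 `CCOC(=O)c1cnc(CC2=CCCCC2)nc1NN1C(=O)C=C(C)C1=O` 2000 nM

In a functional assay on Jurkat cells for inhibition of nuclear factor NF-kappa-B complex (Homo sapiens) (on this read-out lower numbers stand for stronger inhibition and higher numbers for weaker inhibition), compound 1 gives 10000 nM and compound 2 gives 2000 nM. Within the data shown here, compound 2 holds the lowest of the two numbers, and the only measured step, a 5.0-fold lower number from compound 1 to compound 2 (0.70 log units; beyond the scatter), is what separates it from compound 1.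

Compound 3 `CCOC(=O)c1cnc(Oc2ccccc2)nc1NN1C(=O)C=C(C)C1=O` differs from compound 2 by phenoxy in place of (cyclohex-1-en-1-yl)methyl on an aromatic carbon. Among the measured compounds shown here, no measured step covers a phenoxy group at this carbon; the one step at hand, a 5.0-fold lower number from compound 1 to compound 2 (0.70 log units; beyond the scatter), shows only that a change there can move the number modestly. The step is therefore expected to be a 2.0-fold higher number from compound 2 to compound 3 (0.30 log units; within the scatter), a small move toward weaker inhibition, with wide uncertainty. Compound 3 is expected to give 4000 nM in this assay, with a range from 1500 nM to 10000 nM.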

Compound 3, half-maximal inhibitory concentration: 15000 nM
Compound 3: middle estimate off by 3.8-fold (0.57 log units), on the low side, and the stated range ends below it.
By their numbers in this assay, from the lowest: compound 2; then compounds 1 and 3 (each within the scatter of the next).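

In this assay phenoxy on the aromatic carbon between two ring nitrogen atoms gives a 7.5-fold higher number from compound 2 to compound 3 (0.88 log units; beyond the scatter) even though both groups hold 7 heavy atoms, so the lower number does not extend to every group of that size. Phenoxy and 3,5-dimethyl-1H-pyrazol-1-yl cannot be told apart here, with a 1.5-fold higher number from compound 1 to compound 3 (0.18 log units; within the scatter) and thus (cyclohex-1-en-1-yl)methyl alone stands out among the three. No evidence at hand accounts for this difference.

Still open, going by these compounds, is whether the non-aromatic ring or the link to the core matters more. A benzyl or cyclohexyloxy group at this carbon would separate the two.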